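Swapping a Pyrazine Ether for a Cyclobutyl Ether

A few compounds are considered here, and "the series" means these few. Any claim that something is new, unique, unknown or untested is made for them only; others in the source may bear on it.

Of the compounds shown here, three sharing one core have been measured in an ADME assay on the whole organism (Rattus norvegicus) for pharmacokinetics, using cassette dosing, at a dose of 1 mg/kg by the oral route; on this read-out higher numbers stand for higher oral bioavailability and lower numbers for lower oral bioavailability. Compound 1 `CC(C)Oc1ccc(/N=c2\[nH]c(=O)n(C[C@H](C)C(=O)O)c(=O)n2Cc2ccc(Cl)cc2)cc1Cl` gives 82.4%. Compound 2 `C[C@@H](Cn1c(=O)[nH]/c(=N\c2ccc(Oc3ccsn3)cc2)n(Cc2ccc(Cl)cc2)c1=O)C(=O)O` gives 87.6%. Compound 3 `C[C@@H](Cn1c(=O)[nH]/c(=N\c2ccc(Oc3cnccn3)cc2)n(Cc2ccc(Cl)cc2)c1=O)C(=O)O` gives 56.5%, the lowest of the three numbers, separated from both others by more than the usual scatter.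

Compound 4 `C[C@@H](Cn1c(=O)[nH]/c(=N\c2ccc(OC3CCC3)cc2)n(Cc2ccc(Cl)cc2)c1=O)C(=O)O` has not been measured; it differs from compound 3 in one place: cyclobutyl in place of pyrazin-2-yl on an oxygen on an aromatic ring. Going by the values given here, only one measured step changes the group on that oxygen, a number 31.1 percentage points lower from compound 2 to compound 3 (beyond the scatter), and it shows that this part of the molecule can move the read-out a long way. Compound 1 differs from the others in several places and reaches 82.4%, and compound 2 reaches 87.6%, so two of three measured compounds sit high. Among the compounds with values here, putting a four-membered non-aromatic ring of carbon only in place of pyrazin-2-yl is expected to raise the number, although no measured step copies this exact change and the uncertainty is wide. The expected step is a number 18.5 percentage points higher from compound 3 to compound 4 (beyond the scatter). Compound 4 is estimated at 75%, within 50% to 95%.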

Compound 4, oral bioavailability: 54.3%
The estimate for compound 4 lay 20.7 percentage points above the measured number; the range from low to high includes it.
By their numbers in this assay, from the lowest: compounds 4 and 3 (each within the scatter of the next); then compounds 1 and 2 (each within the scatter of the next).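

In this assay, cyclobutyl and pyrazin-2-yl on this oxygen cannot be told apart (a number 2.2 percentage points lower from compound 3 to compound 4 (within the scatter)). A four-membered non-aromatic ring of carbon only therefore reads level with a six-membered aromatic ring with 2 hetero atoms, so the presence or absence of an aromatic ring on the oxygen does not by itself set the number in these two compounds. The high values belong to other groups: 1,2-thiazol-3-yl in place of cyclobutyl gives a clear gap (a number 33.3 percentage points lower from compound 2 to compound 4 (beyond the scatter)), and the 3-chloro-4-isopropoxyphenyl of compound 1 does too (a number 28.1 percentage points lower from compound 1 to compound 4 (beyond the scatter)).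

Nothing available here explains why these groups differ. Also open, going by these compounds, is what a piperidin-4-yl group, which carries an amine, or a longer chain such as n-butyl would give on this oxygen.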